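Chloro for Trifluoromethyl: an Expected Cytotoxicity Value

The compounds below may be only part of what the source reports. "The series", "measured", "known", "first", "only" and "open" are said of these compounds alone.

Measured compounds:
- compound 1 `Nc1ccc(/C=C2\SC(=O)N(Cc3ccc(C(F)(F)F)cc3)C2=O)cc1`: 134000 nM
- compound 2 `C=C(Br)C(=O)Nc1ccc(/C=C2\SC(=O)N(Cc3ccc(C(F)(F)F)cc3)C2=O)cc1`: 23000 nM
- compound 3 `Nc1cccc(/C=C2\SC(=O)N(Cc3ccccc3)C2=O)c1`: > 250000 nM, a limit of the assay rather than a number

In a functional assay on FM3A cells (Mus musculus) for cytotoxicity, read by cell counting, with a stated time of 2 days (on this read-out higher numbers stand for weaker inhibition and lower numbers for stronger inhibition), compound 1 gives 134000 nM, the highest of the two numbers reported. Going by the values given here, the only measured step, a 5.8-fold lower number from compound 1 to compound 2 (0.77 log units; beyond the scatter), concerns a change at the aromatic amine, not the benzyl substituent. Compound 3 sits at the limit of > 250000 nM in this assay, at which 1 of the 3 values shown sits, which is a limit and not a number.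

Compound 4 `Nc1ccc(/C=C2\SC(=O)N(Cc3ccc(Cl)cc3)C2=O)cc1` differs from compound 1 by chloro in place of trifluoromethyl on an aromatic carbon. Among the compounds with values here, no measured step touches this position, so no change beyond the scatter is expected in this assay. Compound 4 is therefore estimated at 134000 nM, with a range from 50000 nM to 350000 nM. This means that no change at the digits printed from compound 1 to compound 4 (within the scatter) is expected.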

Compound 4, half-maximal inhibitory concentration: 60000 nM
The estimate for compound 4 lay 2.2-fold (0.35 log units) above the measured number; low and high end bracket the measured number.
By their numbers in this assay, from the lowest: compound 2; then compound 4; then compound 1. At a limit, above all of these: compound 3.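

Going by these compounds alone, the first measured step at this aromatic carbon, a 2.2-fold lower number from compound 1 to compound 4 (0.35 log units; beyond the scatter), shows that the number in this assay responds to the group held there, and not only to a change at the aromatic amine. Replacing trifluoromethyl with chloro, a single heavy atom in place of four, gives a modest shift. Nothing shown accounts for this step.

Going by these compounds, whether a methoxy group, a nitrile or plain hydrogen on this carbon would move the number further remains open. So does whether chloro would give a similar step with the (1-bromoethenyl)carbonyl group of compound 2 in place.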